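The source may report more compounds than this note shows. Statements on the series, on what has been measured and on what is new or still open speak of the compounds shown alone.

The measured compounds in a functional assay on MCF7 cells (Homo sapiens) for cytotoxicity, read by sulforhodamine B assay, with a stated time of 48 h, tested at 0.01 uM; a higher number here means a weaker effect of the compound at the concentration tested, a lower number a stronger effect:

Compound 1 `COc1cc(-c2cc(/C=C/C(=O)c3ccc(N)cc3)[nH]n2)cc(OC)c1OC`: 89%
Compound 2 `COc1cc(-c2cc(/C=C/C(=O)c3ccc(Cl)c(Cl)c3)[nH]n2)cc(OC)c1OC`: 105%
Compound 3 `COc1ccc(C(=O)/C=C/c2cc(-c3cc(OC)c(OC)c(OC)c3)n[nH]2)cc1OC`: 89%

Compound 3 stands level with compound 1, the two together the lowest of the three numbers, while the step of a number 16 percentage points lower from compound 2 to compound 3 (beyond the scatter) is modest but beyond the scatter. Compound 4 `COc1ccc(C(=O)/C=C/c2cc(-c3cc(OC)c(OC)c(OC)c3)n[nH]2)cc1` differs from compound 3 in one place: hydrogen in place of methoxy on an aromatic carbon. The measured steps all exchange the whole aryl group on the carbonyl carbon; none removes a single methoxy. Still, they show that even a full exchange here moves the read-out little, as in no change at the digits printed from compound 1 to compound 3 (within the scatter) and a number 16 percentage points lower from compound 2 to compound 3 (beyond the scatter). A small step, likely within the scatter, is therefore expected: a number 3 percentage points higher from compound 3 to compound 4 (within the scatter). Compound 4 is estimated at 92%, between 78% and 106%.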

Compound 4, a percentage reported as activity, at one concentration (the size of the read-out at that concentration, not a potency): 101%
Beside the measured number, compound 4's estimate is 9 percentage points below it, within the range that was stated.
By their numbers in this assay, from the lowest: compounds 1 and 3 (each within the scatter of the next); then compounds 4 and 2 (each within the scatter of the next).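

Losing one methoxy alone, going from 3,4-dimethoxyphenyl to 4-methoxyphenyl, registers in this assay as a number 12 percentage points higher from compound 3 to compound 4 (beyond the scatter) and so a single group at this position counts, though modestly. The 4-methoxyphenyl group also differs from 4-aminophenyl, with a number 12 percentage points higher from compound 1 to compound 4 (beyond the scatter) as the step, while a number 4 percentage points lower from compound 2 to compound 4 (within the scatter) leaves it level with 3,4-dichlorophenyl.

From the compounds shown here alone, whether a hydroxyl group or an amine in place of this methoxy would behave like the methoxy or like hydrogen stays open. No measurement shown explains these steps.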